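The source may report more compounds than this note shows. Statements on the series, on what has been measured and on what is new or still open speak of the compounds shown alone.

Measured so far in a functional assay on PC-3 cells (Homo sapiens) for antiproliferative activity, read by MTT assay, with a stated time of 48 h; on this read-out lower numbers stand for stronger inhibition and higher numbers for weaker inhibition:
Compound 1 `COc1cc(N(Cc2ccc(C)cc2)C(=O)CSc2nc3ccccc3s2)cc(OC)c1OC`: > 80000 nM (a limit)
Compound 2 `COc1ccc(CN(C(=O)CSc2nc3ccccc3s2)c2cc(OC)c(OC)c(OC)c2)cc1`: 8460 nM

Compound 1 has no exact number in this assay and stands at the limit of > 80000 nM in this assay, at which 1 of the 2 values shown sits. Compound 3 `COc1ccc(CN(C(=O)CSc2nc3ccccc3s2)c2cc(OC)c(OC)c(OC)c2)cc1[N+](=O)[O-]` has not yet been measured. Its difference from compound 1 is 4-methoxy-3-nitrophenyl in place of 4-methylphenyl on a saturated chain carbon bound to an amide-type nitrogen. In words, it has 4-methoxy-3-nitrophenyl in place of 4-methylphenyl on a saturated chain carbon bound to an amide-type nitrogen.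

Among the measured compounds shown here, one measured step bears on this change: an at least 9.4-fold lower number from compound 1 to compound 2 (0.97 log units; beyond the scatter), with methoxy in place of methyl on an aromatic carbon. Compound 3 carries that same methoxy in place of the methyl, so a lower number is expected in this assay, of a size similar to that step. For the measured compounds named here, the nitro group in compound 3 has no measured counterpart here, which leaves the expectation wide. The expected change is an at least 10-fold lower number from compound 1 to compound 3 (1.00 log units; beyond the scatter). The estimated value for compound 3 is 8000 nM. The expected range for compound 3 runs from 2000 nM to 35000 nM.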

Compound 3, half-maximal inhibitory concentration: 26500 nM
For compound 3 the middle estimate is 3.3-fold (0.52 log units) below the measured one; low and high end bracket the measured number.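

In this assay, the nitro group now has a measured effect of its own: nitro in place of hydrogen on an aromatic carbon gives a 3.1-fold higher number from compound 2 to compound 3 (0.50 log units; beyond the scatter), so on this benzyl group the added nitro weakens inhibition rather than strengthening it. Even so, the whole change from 4-methylphenyl to 4-methoxy-3-nitrophenyl on the saturated chain carbon bound to the amide-type nitrogen still gives an at least 3.0-fold lower number from compound 1 to compound 3 (0.47 log units; beyond the scatter), which shows that the nitro takes back only part of what the methoxy in place of the methyl gained. Compound 1 carries only a limit in this assay, so this last step has a bound and not an exact size: the limit of > 80000 nM in this assay, at which 1 of the 3 values shown sits.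

From the compounds shown here alone, what remains open is whether the weakening in this assay is particular to the nitro, since an amine or a hydroxy group in its place could read quite differently. Going by these compounds, it is also open how far the methoxy itself can be varied, for instance to an ethoxy or a longer alkoxy chain, and whether such a change would move the read-out in the same direction as the step from methyl to methoxy.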